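A 2-Chlorophenyl Enone Built from Three Inactive Relatives

The compounds below may be only part of what the source reports. "The series", "measured", "known", "first", "only" and "open" are said of these compounds alone.

Compound 1 `CCC(/C=C(\COC(C)=O)C(=O)c1ccc(OC)cc1)CC` is the simplest of three close relatives of a shared core examined in a functional assay on A549 cells (Homo sapiens) for inhibition, read by XTT assay, with a stated time of 48 h; on this read-out lower numbers stand for stronger inhibition and higher numbers for weaker inhibition. In this assay compound 1 reaches only the assay limit of > 100000 nM. Compound 2 `CCC(/C=C(\COC(=O)c1ccccc1)C(=O)c1ccc(OC)cc1)CC` carries phenyl in place of methyl on a carbonyl carbon. In this assay compound 2 likewise returns only the limit of > 100000 nM. Compound 3 `CCC(/C=C(\CCOC(C)=O)C(=O)c1ccc(OC)cc1)CC` instead has acetoxymethyl in place of acetoxy on a saturated chain carbon bound to a double-bonded chain carbon. In this assay compound 3 also stops at the limit of > 100000 nM. Compound 3 therefore has no readable standing among the numbers shown, since (the limit of > 100000 nM in this assay, at which 3 of the 3 values shown sit). The steps a step that the two limits leave unreadable from compound 1 to compound 2, a step that the two limits leave unreadable from compound 1 to compound 3 and a step that the two limits leave unreadable from compound 2 to compound 3 are all hidden in the same way.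

Compound 4 `COc1ccc(C(=O)/C(=C/c2ccccc2Cl)CCOC(C)=O)cc1` is not yet measured. It differs from compound 3 by 2-chlorophenyl in place of pentan-3-yl on a double-bonded chain carbon bound to a double-bonded chain carbon. Going by the values given here, none of the measured steps touches this position; each concerns the ester side chain, and each is masked by the limit, so they offer no guide to the size or direction of the change. Among the compounds with values here, the step estimated here, an at least 1.6-fold lower number from compound 3 to compound 4 (0.22 log units; that floor lies within the scatter), thus rests on no measured precedent. Compound 4 is accordingly expected to give about 60000 nM in this assay, with a broad estimated range from 5000 nM to 200000 nM, and it may well again return only a limit.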

Compound 4, half-maximal inhibitory concentration: > 100000 nM
Compound 4: a limit, no number; the forecaster's own chance of this, stated with the estimate: 55%; middle value at least 1.6-fold (0.22 log units) from the limit.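

Compound 4, like compound 3, returns only a limit in this assay, so the step between them cannot be read, and neither can any other step among the four compounds: the limit of > 100000 nM in this assay, at which 4 of the 4 values shown sit.

The compounds shown leave open whether any of the four truly differs from another, and which change to the shared core, if any, would give a readable number.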